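Thiourea series: phenyl replacing acetyl on the amide nitrogen

This account rests on a few compounds, and the source may have more. Where it says the series, first, only, none or still open, it means among the compounds named here.

compound 1 `Fc1ccc(NC(=S)Nc2cccc(C(F)(F)F)c2)cc1`: 40000 nM
compound 2 `CC(=O)NC(=S)Nc1cccc(C(F)(F)F)c1`: > 100000 nM

In an ADME assay on Vero 76 cells (Chlorocebus sabaeus) for cytotoxicity, read by crystal violet staining, with a stated time of 96 h (on this read-out lower numbers stand for higher toxicity in this test and higher numbers for lower toxicity in this test), compound 1 gives 40000 nM. For compound 2 only a limit is known, > 100000 nM, so compound 2 stands at the upper edge of what this assay reports (the limit of > 100000 nM in this assay, at which 1 of the 2 values shown sits). Compound 3 `FC(F)(F)c1cccc(NC(=S)Nc2ccccc2)c1` differs from compound 2 by phenyl in place of acetyl on an amide-type nitrogen. Within the data shown here, the only measured step, an at least 2.5-fold higher number from compound 1 to compound 2 (0.39 log units; beyond the scatter), is the reverse kind of change, so a lower number of at least modest size is expected, an at least 2.2-fold lower number from compound 2 to compound 3 (0.34 log units; beyond the scatter). Compound 3 is therefore estimated at 45000 nM, between 15000 nM and 100000 nM.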

Compound 3, half-maximal cytotoxic concentration: 39000 nM
For compound 3 the middle estimate is 1.2-fold (0.06 log units) above the measured one; the range from low to high includes it.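

On the amide-type nitrogen, phenyl in place of acetyl gives an at least 2.5-fold lower number from compound 2 to compound 3 (0.40 log units; beyond the scatter). Compound 2 carries only a limit in this assay: the limit of > 100000 nM in this assay, at which 1 of the 3 values shown sits.

Hydrogen in place of fluoro on the aromatic carbon gives a 1.0-fold lower number from compound 1 to compound 3 (0.01 log units; within the scatter), so compound 1 and compound 3 cannot be told apart here, and the fluoro is not needed for the step away from acetyl.

As far as these compounds go, whether an amine or a carboxylic acid on that phenyl, or a longer chain in its place on the nitrogen, would shift the number stays open. From the compounds shown here alone, how far compound 2 lies past its limit also stays open.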